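Nitro for Chloro on an Oxazoline Ether Series

A few compounds are considered here, and "the series" means these few. Any claim that something is new, unique, unknown or untested is made for them only; others in the source may bear on it.

Among the measured compounds shown here, the three compounds measured so far share one core, each tested in a toxicity assay on the whole organism with Rattus norvegicus as the target, at a dose of 400 mg/kg by the oral route; on this read-out higher numbers stand for a stronger effect at the one dose given and lower numbers for a weaker effect. Compound 1 `Clc1ccc(OCC2=NCCO2)cc1` gives 12% and stands lowest of the three numbers. For the measured compounds named here, its nearest neighbour is compound 2 `Cc1cc(OCC2=NCCO2)ccc1Cl`, which gives 40% in this assay; the one step that joins two compounds differing in a single place is a number 28 percentage points higher from compound 1 to compound 2 (beyond the scatter), a methyl in place of hydrogen on an aromatic carbon. Compound 3 `O=[N+]([O-])c1ccccc1OCC1=NCCO1`, which also carries a nitro group, gives 45% in this assay, the furthest number from compound 1.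

The next compound, compound 4 `O=[N+]([O-])c1ccc(OCC2=NCCO2)cc1`, is not yet measured. It differs from compound 1 by nitro in place of chloro on an aromatic carbon. Going by the values given here, no measured step bears directly on this change; the one measured step, from compound 1 to compound 2, was modest and upward, and compound 3, the other nitro-bearing compound, sits well above compound 1. On this basis compound 4 is expected to move upward from compound 1, by an estimated a number 23 percentage points higher from compound 1 to compound 4 (beyond the scatter). Compound 4 is therefore estimated at 35% in this assay, within a range from 15% to 55%.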

Compound 4, a percentage reported as activity, at one dose (the size of the read-out at that dose, not a potency): 20%
Beside the measured number, compound 4's estimate is 15 percentage points above it; the range from low to high includes it.
By their numbers in this assay, from the lowest: compounds 1 and 4 (each within the scatter of the next); then compounds 2 and 3 (each within the scatter of the next).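

In this assay, nitro in place of chloro on the aromatic carbon para to a group of 7 heavy atoms gives a number 8 percentage points higher from compound 1 to compound 4 (within the scatter), so this read-out does not separate the two groups at this position. That holds even though nitro brings 3 heavy atoms where chloro has 1, and 2 hydrogen-bond acceptors where chloro has 0. The nitro group alone also does not go with a single level in this series, since compound 3 gives 45% and compound 4 gives 20%, and no measurement shown here offers a reason for this result.

Going by these compounds, whether an amine, a carboxylic acid or a longer chain on this same aromatic carbon would also stay within the scatter of compound 1 remains open. Also open, on these data alone, is whether the methyl that gave a number 28 percentage points higher from compound 1 to compound 2 (beyond the scatter) would do the same on a ring carrying nitro in place of chloro.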